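A few compounds are considered here, and "the series" means these few. Any claim that something is new, unique, unknown or untested is made for them only; others in the source may bear on it.

Three compounds of the series share one core. Compound 1 `O=C(Nc1ccccc1)Nc1ccc(Oc2ccc(-c3ncc[nH]3)cc2)cc1` gives 11.4% in a functional assay on MDA-MB-231 cells (Homo sapiens) for inhibition, read by MTT assay and WST assay, with a stated time of 72 h, tested at 10 uM; on this read-out lower numbers stand for less inhibition of growth and higher numbers for more inhibition of growth at the one concentration tested. Compound 2 `O=C(Nc1ccc(Oc2ccc(-c3ncc[nH]3)cc2)cc1)Nc1cccc(C(F)(F)F)c1` gives 28.1% in this assay, and compound 3 `O=C(Nc1ccc(Oc2ccc(-c3ncc[nH]3)cc2)cc1)Nc1ccc(F)c(C(F)(F)F)c1` gives 26.6% in this assay. Compound 3 stands second highest of the three, within the scatter of compound 2 and beyond the scatter above compound 1.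

Compound 4 `Cc1ccc(NC(=O)Nc2ccc(Oc3ccc(-c4ncc[nH]4)cc3)cc2)cc1` differs from compound 3 by 4-methylphenyl in place of 4-fluoro-3-(trifluoromethyl)phenyl on an amide-type nitrogen. Among the measured compounds shown here, the steps that bear on this: a number 15.2 percentage points higher from compound 1 to compound 3 (beyond the scatter) and a number 16.7 percentage points higher from compound 1 to compound 2 (beyond the scatter), while a number 1.5 percentage points lower from compound 2 to compound 3 (within the scatter). Compound 4 gives up the 4-fluoro-3-(trifluoromethyl)phenyl for a phenyl bearing only a methyl, nearer to compound 1, so a modest downward step is expected, a number 11.6 percentage points lower from compound 3 to compound 4 (beyond the scatter) in this assay. Compound 4 is therefore estimated at 15%, with a range from 5% to 28%.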

Compound 4, percent growth inhibition at one concentration: 49.3%
Compound 4: middle estimate off by 34.3 percentage points, on the low side; measured number outside the range, above it.
By their numbers in this assay, from the lowest: compound 1; then compounds 3 and 2 (each within the scatter of the next); then compound 4.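

In this assay a methyl on the phenyl at the amide-type nitrogen gives a number 37.9 percentage points higher from compound 1 to compound 4 (beyond the scatter) and goes past both trifluoromethyl-bearing groups, with a number 21.2 percentage points higher from compound 2 to compound 4 (beyond the scatter) and a number 22.7 percentage points higher from compound 3 to compound 4 (beyond the scatter) on top of what those groups had gained. Fluorine is therefore not needed for a rise at this position, and the trifluoromethyl groups do not mark its upper end among the compounds shown. Nothing on hand explains the order of these groups.

Open, on these data alone, is whether the rise is specific to methyl or also holds for an ethyl, a methoxy or an amine in its place. The single tested concentration leaves open how far the order would carry over to a full dose-response curve.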